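A Phenyl Added to the Carboxymethyl Arm

This account rests on a few compounds, and the source may have more. Where it says the series, first, only, none or still open, it means among the compounds named here.

Among the measured compounds in a functional assay on K562 cells (Homo sapiens) for cytotoxicity, read by trypan blue exclusion, with a stated time of 96 h (a higher number here means a weaker inhibitor, a lower number a stronger inhibitor), compound 3 `COc1cc(OC)c(/C=C/S(=O)(=O)Nc2ccc(OC)c(NCC(=O)O)c2)c(OC)c1` stands lowest at 20 nM while compound 1 `COc1cc(OC)c(/C=C/S(=O)(=O)Nc2ccc(OC)c(F)c2)c(OC)c1` gives 75 nM and compound 2 `COC(=O)C(Nc1cc(NS(=O)(=O)/C=C/c2c(OC)cc(OC)cc2OC)ccc1OC)c1ccccc1` gives 2500 nM in the same read-out. Compound 4 `COc1cc(OC)c(/C=C/S(=O)(=O)Nc2ccc(OC)c(NC(C(=O)O)c3ccccc3)c2)c(OC)c1` carries the change phenyl in place of hydrogen on a saturated chain carbon bound to a carbonyl carbon and a nitrogen on an aromatic ring so that carboxymethyl becomes carboxy(phenyl)methyl. Compound 2 also bears a phenyl on that carbon, but with methoxycarbonyl in place of the carboxy group. The large step of a 130-fold lower number from compound 2 to compound 3 (2.10 log units; beyond the scatter) therefore combines two changes, and the data do not separate them. Two further steps from the fluoro compound frame the question: the large 33-fold higher number from compound 1 to compound 2 (1.52 log units; beyond the scatter) with the phenyl-bearing group, and the modest 3.8-fold lower number from compound 1 to compound 3 (0.57 log units; beyond the scatter) without it. Compound 4 should thus take up part of that large difference. A rise of moderate size is expected, stated as a 7.5-fold higher number from compound 3 to compound 4 (0.88 log units; beyond the scatter) in this assay as an estimate. Compound 4 is expected at 150 nM with an estimated range from 25 nM to 900 nM in this measurement.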

Compound 4, half-maximal inhibitory concentration: 300 nM
For compound 4 the middle estimate is 2.0-fold (0.30 log units) below the measured one; the measured number falls inside the stated range.
By their numbers in this assay, from the lowest: compound 3; then compound 1; then compound 4; then compound 2.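

In this assay, compound 4 separates the two changes that were combined between compound 2 and compound 3: phenyl in place of hydrogen alone gives a 15-fold higher number from compound 3 to compound 4 (1.18 log units; beyond the scatter) and, with the phenyl kept, carboxy in place of methoxycarbonyl alone gives an 8.3-fold lower number from compound 2 to compound 4 (0.92 log units; beyond the scatter), so each change by itself moves the number beyond the scatter. The phenyl also reverses the comparison with fluoro, since (carboxymethyl)amino gave a 3.8-fold lower number from compound 1 to compound 3 (0.57 log units; beyond the scatter) whereas (carboxy(phenyl)methyl)amino gives a 4.0-fold higher number from compound 1 to compound 4 (0.60 log units; beyond the scatter) in the same read-out. No measurement at hand bears on why these numbers shift.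

Going by these compounds, whether a smaller group on the same saturated chain carbon, such as methyl, would keep the number close to that of compound 3 remains open. So does the outcome of a primary amide in place of the carboxy group, with or without the phenyl.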